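Tert-butyl in place of fluoro on an aromatic carbon

This account rests on a few compounds, and the source may have more. Where it says the series, first, only, none or still open, it means among the compounds named here.

In a functional assay on HCT-116 cells (Homo sapiens) for antiproliferative activity, read by MTT assay, with a stated time of 72 h (a lower number here means a stronger inhibitor, a higher number a weaker inhibitor), three compounds with a shared core have been measured. Compound 1 `NC1=NC2(CCOCC2)N(OCCCOc2ccccc2)C(N)=N1` gives 6010 nM, compound 2 `NC1=NC2(CCOCC2)N(OCCCOc2ccc(F)cc2)C(N)=N1` gives 3280 nM, and compound 3 `NC1=NC2(CCOCC2)N(OCCCOc2ccc(Cl)c(Cl)c2)C(N)=N1` gives 90 nM. Fluoro in place of hydrogen on an aromatic carbon makes only a small difference: a 1.8-fold lower number from compound 1 to compound 2 (0.26 log units; within the scatter). The 3,4-dichlorophenyl group separates the other pairs by much more: a 67-fold lower number from compound 1 to compound 3 (1.82 log units; beyond the scatter) and a 36-fold lower number from compound 2 to compound 3 (1.56 log units; beyond the scatter). Compound 2 therefore stands with compound 1, far from compound 3.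

Compound 4 `CC(C)(C)c1ccc(OCCCON2C(N)=NC(N)=NC23CCOCC3)cc1` differs from compound 2 in one place, with tert-butyl in place of fluoro on an aromatic carbon, para to a large group: tert-butyl in place of fluoro on an aromatic carbon. For the measured compounds named here, no measured step makes this exact exchange, so the evidence is indirect. Compound 3 at 90 nM shows that substitution on this aromatic ring can lower the number greatly, though compound 2 at 3280 nM shows that it need not. Going by the values given here, a lower number is therefore expected, but by a smaller step than the one to compound 3, and with wide uncertainty. The expected change is a 6.6-fold lower number from compound 2 to compound 4 (0.82 log units; beyond the scatter). For compound 4 the estimated value is 500 nM, within an expected range from 100 nM to 2500 nM.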

Compound 4, half-maximal inhibitory concentration: 1610 nM
The estimate for compound 4 lay 3.2-fold (0.51 log units) below the measured number, and the stated range covers the measured number.
By their numbers in this assay, from the lowest: compound 3; then compound 4; then compounds 2 and 1 (each within the scatter of the next).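

In this assay, tert-butyl para to a large group gives a 2.0-fold lower number from compound 2 to compound 4 (0.31 log units; beyond the scatter), and set against hydrogen in the same place it gives a 3.7-fold lower number from compound 1 to compound 4 (0.57 log units; beyond the scatter). For the compounds shown here, this makes tert-butyl the first single group at this position whose step from hydrogen lies beyond the scatter, whereas fluoro gave only a 1.8-fold lower number from compound 1 to compound 2 (0.26 log units; within the scatter). Going from one heavy atom to four heavy atoms at this position still yields only a modest step, so the large step, a 67-fold lower number from compound 1 to compound 3 (1.82 log units; beyond the scatter), remains confined to the 3,4-dichlorophenyl group. No measurement here bears on why these steps differ in size.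

The compounds shown leave open how a single chloro or a methoxy group in the same place would compare with tert-butyl, and so whether the size of the group tracks the number at all. They also leave open whether the large step needs both chloro groups of compound 3, and whether it would survive a longer chain between the aromatic ring and the shared core.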